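Cytotoxicity in TZM cells: from a difluorophenyl to a cyanophenyl

The compounds below may be only part of what the source reports. "The series", "measured", "known", "first", "only" and "open" are said of these compounds alone.

Compound 1 `Cc1ccc(NS(=O)(=O)N2C(=O)CSC2c2c(F)cccc2Cl)cc1`: 136000 nM
Compound 2 `COc1cc(OC)nc(N2C(=O)CSC2c2c(Cl)cccc2Cl)n1`: 85400 nM
Compound 3 `COc1cc(OC)nc(N2C(=O)CSC2c2c(F)cccc2F)n1`: 77500 nM

Of the compounds shown here, three have been measured in an ADME assay on TZM cells (Homo sapiens) for cytotoxicity, read by MTT assay, with a stated time of 48 h; a higher number here means that more compound is tolerated, a lower number that less compound is tolerated. Compound 3 gives 77500 nM and sits at the low end of the three numbers, but neither compound 2 with 85400 nM nor compound 1 with 136000 nM stands apart from it beyond the scatter. Among the compounds with values here, the single step that has been measured at the same place is a 1.1-fold lower number from compound 2 to compound 3 (0.04 log units; within the scatter), so the one change seen so far at this position left the number essentially unmoved.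

Compound 4 `COc1cc(OC)nc(N2C(=O)CSC2c2ccc(C#N)cc2)n1` carries 4-cyanophenyl in place of 2,6-difluorophenyl on a saturated ring carbon. Within the data shown here, no measured step shows an aromatic ring without the two halogens, nor one bearing a nitrile, so the only guide is the flat step from compound 2 to compound 3. On that basis the author expects compound 4 to show no shift beyond the scatter in this assay, an expected step of a 1.0-fold higher number from compound 3 to compound 4 (0.01 log units; within the scatter). The estimate for compound 4 is 80000 nM, with a range from 35000 nM to 180000 nM.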

Compound 4, half-maximal cytotoxic concentration: 86500 nM
Compound 4: the middle estimate sits 1.1-fold (0.03 log units) below what was measured, and the stated range covers the measured number.
By their numbers in this assay, from the lowest: compounds 3, 2, 4 and 1 (each within the scatter of the next).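

In this assay, the earlier compounds had shown only one halogen pair exchanged for another at this saturated ring carbon, with the two halogens kept on the aromatic ring. With 4-cyanophenyl, both halogens leave and a nitrile enters, yet the exchange gives a 1.1-fold higher number from compound 3 to compound 4 (0.05 log units; within the scatter) and a 1.0-fold higher number from compound 2 to compound 4 (0.01 log units; within the scatter) on the shared core, so compounds 2, 3 and 4 show that this larger change at this position also stays within the scatter. Nothing measured here bears on the reason for this flat result.

From the compounds shown here alone, it remains open whether an amine or a carboxylic acid on the aromatic ring, or a longer alkyl chain in its place, would move the number beyond the scatter. Going by these compounds, it is also open whether 4-cyanophenyl would behave the same way on the core of compound 1.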